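The compounds below may be only part of what the source reports. "The series", "measured", "known", "first", "only" and "open" are said of these compounds alone.

Three members of this series have been tested in a functional assay on DU-145 cells (Homo sapiens) for antiproliferative activity, read by MTT assay, with a stated time of 72 h; on this read-out higher numbers stand for weaker inhibition and lower numbers for stronger inhibition. Compound 1, with the structure `c1ccc(COc2cccc(Nc3ncnc4cc5c(cc34)OCCOCCO5)c2)cc1`, gives only a limit in this assay, > 100000 nM. Compound 2, `FC(F)(F)c1ccc(COc2ccccc2Nc2ncnc3cc4c(cc23)OCCOCCOCCO4)cc1`, likewise returns a limit, > 100000 nM. Among the compounds with values here, compound 3, `FC(F)(F)c1ccc(COc2cccc(Nc3ncnc4cc5c(cc34)OCCOCCOCCOCCO5)c2)cc1`, is the one member with a measured number: in this assay compound 3 gives 26900 nM. Within the data shown here, compound 3 therefore stands as the only quantified value in the set, the other two sitting at the limit of > 100000 nM in this assay, at which 2 of the 3 values shown sit.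

The next compound, compound 4, has the structure `O=[N+]([O-])c1ccc(COc2cccc(Nc3ncnc4cc5c(cc34)OCCOCCOCCOCCO5)c2)cc1`. It differs from compound 3 in one place: nitro in place of trifluoromethyl on an aromatic carbon. Among the measured compounds shown here, no measured step between two compounds in this set separates the effect of such a swap, so the expectation rests on compound 3 alone.

Both groups are substituents without a ring on the same aromatic carbon, and the rest of the molecule is unchanged, so the step from compound 3 to compound 4 is expected to be small, within the usual scatter, and is estimated as a 1.1-fold lower number from compound 3 to compound 4 (0.03 log units; within the scatter). Compound 4 is accordingly expected to give about 25000 nM in this assay, with a range from 8000 nM to 80000 nM.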

Compound 4, half-maximal inhibitory concentration: 13800 nM
Compound 4: middle estimate off by 1.8-fold (0.26 log units), on the high side; low and high end bracket the measured number.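

In this assay, the series now has its first measured step at one place, the aromatic carbon para to a large group: a 1.9-fold lower number from compound 3 to compound 4 (0.29 log units; within the scatter), with nitro in place of trifluoromethyl. A group with no hydrogen-bond acceptors thus gives way to one with two, and the two compounds are not separated beyond the scatter, so this pair shows that the exchange is tolerated at this position and that a number can still be read in this assay. Compound 1 and compound 2 add no second number to this comparison, as each gives only a limit of the assay: the limit of > 100000 nM in this assay, at which 2 of the 4 values shown sit.

The compounds shown leave open whether an amine, a carboxylic acid or a nitrile on the same aromatic carbon would stay within the scatter of these two groups or move the number beyond it. Within the data shown here, they also leave open what the substituent and the rest of the molecule each contribute, since compound 1 and compound 2 differ from compound 3 in more than one place and no step involving them can be read.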